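Changing the group on the aromatic ring of a shared core

The compounds below may be only part of what the source reports. "The series", "measured", "known", "first", "only" and "open" are said of these compounds alone.

In an assay for inhibition of inositol hexakisphosphate kinase 2 (Homo sapiens), read by colorimetric assay, coupled enzyme assay and malachite green, with a stated time of 120 min, in the presence of a further agent that is not named here (on this read-out higher numbers stand for weaker inhibition and lower numbers for stronger inhibition), compound 1 `O=C(O)c1ccc2noc(-c3ccc(-c4cccnc4)cc3)c2c1` gives 54 nM. Compound 2 `O=C(O)c1ccc2noc(-c3ccc(Oc4ncc(Cl)cc4Cl)cc3)c2c1` gives 650 nM, the highest of the two numbers; the step of a 12-fold higher number from compound 1 to compound 2 (1.08 log units; beyond the scatter) shows how strongly the group on this aromatic carbon can move the result. Compound 3 `CC(C)C(=O)Nc1ccc(-c2onc3ccc(C(=O)O)cc23)cc1` is not yet measured and differs from compound 2 by (isopropylcarbonyl)amino in place of (3,5-dichloropyridin-2-yl)oxy on an aromatic carbon. Within the data shown here, no measured step makes exactly this change, and the one step available is large, so a shift beyond the scatter in either direction is possible. Compound 3 is expected to give about 200 nM, between 50 nM and 900 nM. That amounts to an estimated step of a 3.3-fold lower number from compound 2 to compound 3 (0.51 log units; beyond the scatter).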

Compound 3, half-maximal inhibitory concentration: 820 nM
The estimate for compound 3 lay 4.1-fold (0.61 log units) below the measured number; the range from low to high includes it.
By their numbers in this assay, from the lowest: compound 1; then compounds 2 and 3 (each within the scatter of the next).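

Replacing (3,5-dichloropyridin-2-yl)oxy, which has a ring, with (isopropylcarbonyl)amino, which has none, gives a 1.3-fold higher number from compound 2 to compound 3 (0.10 log units; within the scatter), so this assay does not separate these two very different groups at this position. Pyridin-3-yl stands apart, with a 15-fold higher number from compound 1 to compound 3 (1.18 log units; beyond the scatter), and since compound 2 also carries a ring, having a ring here does not by itself give the low number of compound 1. Nothing available explains these differences. Going by these compounds, it remains open whether a plain phenyl ring or an amine on this aromatic carbon would give a number like that of compound 1 or like those of compound 2 and compound 3.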